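This account rests on a few compounds, and the source may have more. Where it says the series, first, only, none or still open, it means among the compounds named here.

Measured compounds:
compound 1, `COc1ccc2c(c1)c(C1=CCNCC1)cn2S(=O)(=O)c1ccc2cccnc2c1`, 2 nM
compound 2, `COc1ccc2c(c1)c(C1=CCN(C)CC1)cn2S(=O)(=O)c1ccc2cccnc2c1`, 82 nM
compound 3, `CCCN1CC=C(c2cn(S(=O)(=O)c3ccc4cccnc4c3)c3ccc(OC)cc23)CC1`, 247 nM

Compound 3 stands at the highest number of the three in an assay on HEK293 cells for displacement of a labelled ligand from 5-hydroxytryptamine receptor 6 (Homo sapiens), read by scintillation counting; a lower number here means a stronger inhibitor, a higher number a weaker inhibitor; its nearest neighbour is compound 2, the step of a 3.0-fold higher number from compound 2 to compound 3 (0.48 log units; beyond the scatter), and the furthest is compound 1, the step of a 120-fold higher number from compound 1 to compound 3 (2.09 log units; beyond the scatter). Compound 4, `CCCCN1CC=C(c2cn(S(=O)(=O)c3ccc4cccnc4c3)c3ccc(OC)cc23)CC1`, differs from compound 3 by methyl in place of hydrogen on a saturated chain carbon, three bonds along the chain from an amine nitrogen in a ring. Within the data shown here, of the measured steps, only the one from compound 2 to compound 3 resembles this change, a lengthening of the chain on the ring amine by one carbon, and it was modest: a 3.0-fold higher number from compound 2 to compound 3 (0.48 log units; beyond the scatter). The steps from compound 1 to compound 2 and from compound 1 to compound 3 both concern the substituent on the ring nitrogen as a whole and were large, a 41-fold higher number from compound 1 to compound 2 (1.61 log units; beyond the scatter) and a 120-fold higher number from compound 1 to compound 3 (2.09 log units; beyond the scatter), but they replace a hydrogen on nitrogen and bear on the present change only in showing that each added carbon so far raised the number. Compound 4 is therefore expected to give a slightly higher number again, a step of about a 1.8-fold higher number from compound 3 to compound 4 (0.26 log units; within the scatter), possibly within the scatter. The estimate for compound 4 in this assay is 450 nM, with a range from 180 nM to 1200 nM.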

Compound 4, inhibition constant: 219 nM
Compound 4: the middle estimate sits 2.1-fold (0.31 log units) above what was measured; low and high end bracket the measured number.
By their numbers in this assay, from the lowest: compound 1; then compound 2; then compounds 4 and 3 (each within the scatter of the next).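

In this assay, going from propyl to butyl on the ring nitrogen gave a 1.1-fold lower number from compound 3 to compound 4 (0.05 log units; within the scatter) and so did not extend the rise in the number seen from hydrogen to methyl to propyl. With butyl the number remains far from that of the unsubstituted amine, at a 110-fold higher number from compound 1 to compound 4 (2.04 log units; beyond the scatter) in this series, whereas the gain over methyl is only a 2.7-fold higher number from compound 2 to compound 4 (0.43 log units; beyond the scatter) and about the same as the step from methyl to propyl. Among these four compounds, most of the difference therefore comes with the first substituent on the nitrogen, and beyond propyl the added carbon shows no measurable effect at this position.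

As far as these compounds go, it remains open whether a longer chain such as hexyl, a branched chain such as isopropyl or a benzyl group on the ring nitrogen would stay at this level. No evidence is available to explain the levelling.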